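This account rests on a few compounds, and the source may have more. Where it says the series, first, only, none or still open, it means among the compounds named here.

Measured compounds:
Compound 1, `Fc1ccc(-c2nc3cc(C(F)(F)F)ccc3[nH]2)cc1`: in an ADME assay on Vero cells (Chlorocebus sabaeus) for cytotoxicity (a lower number here means that less compound is tolerated, a higher number that more compound is tolerated), compound 1 gives 60000 nM.
Compound 2, `Fc1cccc(F)c1-c1nc2cc(C(F)(F)F)ccc2[nH]1`: in this assay compound 2 gives 25000 nM.
Compound 3, `O=[N+]([O-])c1ccc(-c2nc3cc(Cl)c(Cl)cc3[nH]2)cc1`: in this assay compound 3 gives >= 100000 nM, which is a limit of the assay and not a number.

Among the two real numbers, compound 1 has the higher one; compound 2 lies below it by a gap beyond the usual scatter. Compound 3 stands at the limit of >= 100000 nM in this assay, at which 1 of the 3 values shown sits.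

Compound 4, `O=C(CCl)Nc1ccc(-c2nc3cc(C(F)(F)F)ccc3[nH]2)cc1`, has not yet been measured in this assay. It differs from compound 1 in one place: ((chloromethyl)carbonyl)amino in place of fluoro on an aromatic carbon. Within the data shown here, no measured pair among the three compounds shows this change, so the size of the step is open. The account expects a step from compound 1 to compound 4 of a 3.0-fold lower number from compound 1 to compound 4 (0.48 log units; beyond the scatter), that is, downward and beyond the scatter, meaning less of compound 4 is expected to be tolerated. For compound 4 the estimate in this assay is 20000 nM, with a range from 5000 nM to 60000 nM.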

Compound 4, half-maximal cytotoxic concentration: 35000 nM
Compound 4: middle estimate off by 1.8-fold (0.24 log units), on the low side; the range from low to high includes it.
By their numbers in this assay, from the lowest: compounds 2, 4 and 1 (each within the scatter of the next, the first and the last beyond it). At a limit, above all of these: compound 3.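

In this assay, among these compounds, the change of fluoro to ((chloromethyl)carbonyl)amino gives the first reading for this position, on an aromatic carbon para to a large group: a 1.7-fold lower number from compound 1 to compound 4 (0.23 log units; within the scatter). A much larger group, bringing a hydrogen-bond donor, a hydrogen-bond acceptor and a chlorine, therefore leaves the number within the scatter of the fluoro compound, so this one change on the core of compound 1 gives no measurable separation. Nothing in the data shown bears on why the two numbers stand so close.

A single change cannot tell whether the chlorine of the new group matters, and a plain acetylamino group would speak to that. From the compounds shown here alone, whether an amine or a carboxylic acid at this position would also stay within the scatter remains open.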